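Series notes: solubility at low pH, step to compound 3

The source may hold more compounds than are shown below. What is called first, only, known or untested is meant among the compounds shown, and "the series" means these compounds.

Of the compounds shown here, two have been measured in a physicochemical assay for solubility, read by HPLC, with a stated time of 12 h, at pH 2; a higher number here means a more soluble compound, a lower number a less soluble compound. Compound 1 `O=c1nc(N2CCN(CC3CCCCC3)CC2)sc2c([N+](=O)[O-])cc(C(F)(F)F)cc12` gives 0.9 ug/mL in this assay. Compound 2 `O=c1nc(N2CCC3(CCN(Cc4ccc(C(F)(F)F)cc4)CC3)CC2)sc2c([N+](=O)[O-])cc(C(F)(F)F)cc12` gives 1.24 ug/mL in this assay. Going by the values given here, the two numbers sit within the scatter of each other, so compound 2 stands at the same level as compound 1 on the numbers so far, and both are sparingly soluble under these conditions. Among the compounds with values here, no step between measured compounds that differ in a single place is available, so nothing about the size of any change is yet known from the series itself.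

Compound 3 `O=c1nc(N2CCC3(CCN(Cc4cccc(F)c4)CC3)CC2)sc2c([N+](=O)[O-])cc(C(F)(F)F)cc12` has not been measured in this assay. It differs from compound 2 in one place: 3-fluorophenyl in place of 4-(trifluoromethyl)phenyl on a saturated chain carbon bound to an amine nitrogen in a ring. Within the data shown here, with no measured step of this kind to lean on, the expectation for compound 3 rests only on compound 2 and its value of 1.24 ug/mL. A modest step upward from compound 2 to compound 3, a 2.4-fold higher number from compound 2 to compound 3 (0.38 log units; beyond the scatter), is expected, though one at the edge of the scatter would not surprise. For compound 3 the expected solubility in this assay is 3 ug/mL, with a range from 1 ug/mL to 9 ug/mL.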

Compound 3, solubility: 1.13 ug/mL
For compound 3 the middle estimate is 2.7-fold (0.42 log units) above the measured one, within the range that was stated.
By their numbers in this assay, from the lowest: compounds 1, 3 and 2 (each within the scatter of the next).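

Notes on the aryl group: the pair compound 2 and compound 3 gives the series its first single-place step, located on a saturated chain carbon bound to an amine nitrogen in a ring. In this assay, 3-fluorophenyl in place of 4-(trifluoromethyl)phenyl gives a 1.1-fold lower number from compound 2 to compound 3 (0.04 log units; within the scatter), so this pair stands at one level even though the group that enters has fewer heavy atoms than the group that leaves and the fluorine count goes from three to one. Nothing at hand accounts for this result.

Both groups in this pair are fluorine-bearing phenyl rings with 0 hydrogen-bond donors, 0 hydrogen-bond acceptors and no net charge, so the step says nothing about how a group of a different kind, such as a dimethylamino group or a carboxylic acid on the ring, or a pyridine in place of the phenyl, would read at this position. Also open, going by these compounds, is whether the same level would hold for this pair of groups on another amine, such as the piperazine side of compound 1, since a single step cannot show how far it carries.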